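A Difluoromethyl Swap on a Low-Toxicity Scaffold

This account rests on a few compounds, and the source may have more. Where it says the series, first, only, none or still open, it means among the compounds named here.

Compound 2 `O=c1n(Cc2nc3ccccc3n2CCCCO)c2cnccc2n1C1CCCC1` was examined in an ADME assay on HEp-2 cells (Homo sapiens) for cytotoxicity; on this read-out lower numbers stand for higher toxicity in this test and higher numbers for lower toxicity in this test. In this assay compound 2 gives only a limit of > 246000 nM, not a number, and one further entry for compound 2 in this assay likewise yields no single number. Two other compounds of the series stand beside it. Compound 1 `CC(C)S(=O)(=O)CCCn1c(Cn2c(=O)n(C3CC3)c3ccncc32)nc2ccccc21` gives 49200 nM in this assay. Compound 3 `CS(=O)(=O)CCCn1c(Cn2c(=O)n(C3CC3)c3ccncc32)nc2ccccc21` gives > 230000 nM; > 227000 nM (2 entries) in this assay across its several entries. Compound 2 thus stands with compound 3 at the edge of the test, while compound 1 is the only one of the three with a measured number, as the limit of > 246000 nM in this assay, at which 1 of the 3 values shown sits, shows.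

The next compound, compound 4 `O=c1n(Cc2nc3ccccc3n2CCCCO)c2cnccc2n1C(F)F`, differs from compound 2 in one place: difluoromethyl in place of cyclopentyl on an aromatic nitrogen. Among the compounds with values here, no step between measured compounds is available, so nothing in the data shows what such a change does in this assay. Compound 2 sits at a limit, and the repeated limits of compound 3 (the several entries of compound 3 in this assay, > 230000 nM; > 227000 nM (2 entries)) show that this series tends to report no number, compound 1 being the exception. For the step from compound 2 to compound 4 no change beyond the scatter is expected, with a step that the limit leaves unreadable from compound 2 to compound 4 as the expected size. The estimate for compound 4 in this assay is 250000 nM, in the range 100000 nM to 600000 nM, most likely again reported as a limit.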

Compound 4, half-maximal cytotoxic concentration: > 186000 nM
Compound 4 was reported as a limit; the forecaster's own chance of this, stated with the estimate: 70%; the middle value does not contradict the limit.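

Compound 2 and compound 4 are both reported only as limits in this assay, so no step can be read between them. The compounds shown leave open whether difluoromethyl in place of cyclopentyl on an aromatic nitrogen changes the half-maximal cytotoxic concentration at all, as neither compound has a single number.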